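This account rests on a few compounds, and the source may have more. Where it says the series, first, only, none or still open, it means among the compounds named here.

Measured so far in a functional assay on HeLa cells (Homo sapiens) for cytotoxicity, read by MTT assay, with a stated time of 48 h; a lower number here means a stronger inhibitor, a higher number a weaker inhibitor:
Compound 1 `CCOC(=O)c1c(-c2c(Cl)c3ccccc3oc2=O)nn(-c2cccc(C)c2)c1C(=O)OCC` gives 30000 nM.
Compound 2 `CCOC(=O)c1c(-c2cc3ccccc3oc2=O)nn(-c2ccc(C)c(C)c2)c1C(=O)OCC` gives 50000 nM.
Compound 3 `COC(=O)c1c(-c2cc3ccccc3oc2=O)nn(-c2cccc(F)c2)c1C(=O)OC` gives 76000 nM.

Compound 2 sits in the middle of the three numbers; its gaps to compound 3 and to compound 1 both lie within the scatter, so the three measured compounds cannot be told apart in this assay, and all are weak.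

Compound 4 `CCOC(=O)c1c(-c2cc3ccccc3oc2=O)nn(-c2ccc(Br)cc2)c1C(=O)OCC` differs from compound 2 by a single change: 4-bromophenyl in place of 3,4-dimethylphenyl on an aromatic nitrogen. Among the measured compounds shown here, no pair of measured compounds shows a step of this kind, so the effect of exchanging one group on that aromatic nitrogen for another is not known from the data. The three measured compounds, which carry different groups on that nitrogen, all fall close together, so no step beyond the scatter is expected from compound 2 to compound 4 in this assay; the estimated step is a 1.1-fold lower number from compound 2 to compound 4 (0.05 log units; within the scatter). Compound 4 is therefore expected to give about 45000 nM, with a range from 20000 nM to 100000 nM.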

Compound 4, half-maximal inhibitory concentration: 250000 nM
Estimate against measurement, compound 4: 5.6-fold (0.74 log units) below; measured number above the stated range.
By their numbers in this assay, from the lowest: compounds 1, 2 and 3 (each within the scatter of the next, the first and the last beyond it); then compound 4.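

In this assay, among the compounds shown here, 4-bromophenyl in place of 3,4-dimethylphenyl on the aromatic nitrogen gives a 5.0-fold higher number from compound 2 to compound 4 (0.70 log units; beyond the scatter) and is the only single-change step read so far. For the compounds shown here, the group on this nitrogen can therefore move the number towards weaker inhibition, which the earlier compounds, differing in more than one place, could not show. No measured evidence accounts for this step. Still open, on these data alone, is whether the bromine or the absence of the two methyl groups carries the step. Also open, as far as these compounds go, is how an amine or a carboxylic acid on that phenyl ring would read.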